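The compounds below may be only part of what the source reports. "The series", "measured", "known", "first", "only" and "open" are said of these compounds alone.

Compound 1 `CC1(c2ccccc2)CC(=O)C(C2CC(c3ccc(-c4ccc(Br)cc4)cc3)Cc3ccccc32)=C(O)O1` is the reference point of this short series. In a functional assay on A549 cells (Homo sapiens) for inhibition, with a stated time of 72 h (a lower number here means a stronger inhibitor, a higher number a weaker inhibitor), compound 1 gives 1830 nM. Compound 2 `CCC1(c2ccccc2)CC(=O)C(C2CC(c3ccc(-c4ccc(Br)cc4)cc3)Cc3ccccc32)=C(O)O1` carries an ethyl where compound 1 carries a methyl on the saturated ring. For compound 2 this assay gives only a limit, > 10000 nM, which is not a number. The step of an at least 5.4-fold higher number from compound 1 to compound 2 (0.73 log units; beyond the scatter) therefore rests on (the limit of > 10000 nM in this assay, at which 1 of the 2 values shown sits), and its true size is not known beyond the stated lower bound.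

Compound 3 `CCC1(c2ccccc2)CC(=O)C(C2CC(c3ccc(OC)cc3)Cc3ccccc32)=C(O)O1` keeps the ethyl of compound 2 and differs from it elsewhere: methoxy in place of 4-bromophenyl on an aromatic carbon, para to a large group. For the measured compounds named here, no measured step concerns this position, so the only comparison that exists, the one between compound 1 and compound 2, bears on a different part of the molecule and gives no guide to the direction of this change. Since compound 2 already sits at the limit of this assay, compound 3 is expected to remain weak, with the step estimated as a step that the limit leaves unreadable from compound 2 to compound 3. The estimate for compound 3 is 15000 nM, within 4000 nM to 60000 nM.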

Compound 3, half-maximal inhibitory concentration: > 10000 nM
Compound 3: only a limit was reported (the forecaster's own chance of this, stated with the estimate: 70%); the middle value lies beyond the limit too.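

In this assay compound 3 gives > 10000 nM, which is a limit and not a number. For the compounds shown here, compound 2 also gives only a limit, so no step from compound 2 to compound 3 can be read: the limit of > 10000 nM in this assay, at which 2 of the 3 values shown sit. The compounds shown leave open how methoxy and 4-bromophenyl compare on this aromatic carbon when the ethyl is present.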